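The source may report more compounds than this note shows. Statements on the series, on what has been measured and on what is new or still open speak of the compounds shown alone.

Measured in an ADME assay on the whole organism (blood, Mus musculus, strain C57BL/6) for pharmacokinetics, read by HPLC, with a stated time of 4 h, at a dose of 2 mg/kg by the intraperitoneal route; a lower number here means less compound in the circulation, a higher number more compound in the circulation at the dose given:
- compound 1 `O=C(Nc1ccc(Cl)c(C(=O)N2CCCCC2)c1O)Nc1cccc(F)c1Cl`: "below limit of detection" (no number reported)
- compound 2 `CN1CCN(S(=O)(=O)c2c(Cl)ccc(NC(=O)Nc3cccc(Cl)c3Cl)c2O)CC1`: 303 ng.h/mL
- compound 3 `CN1CC2(CC(S(=O)(=O)c3c(Cl)ccc(NC(=O)Nc4cccc(F)c4Cl)c3O)C2)C1`: 1050 ng.h/mL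

Compound 1 has as its result a limit of the assay and not a number.

Among the compounds with values here, only two compounds give a number in this assay, and compound 3, at 1050 ng.h/mL, is the higher of them. Compound 2 gives 303 ng.h/mL, a lower number by a gap beyond the usual scatter.

The next compound is compound 4 `CC(C)N1CCN(S(=O)(=O)c2c(Cl)ccc(NC(=O)Nc3cccc(F)c3Cl)c2O)CC1`, which has not yet been measured. It differs from compound 3 in the group on the sulfonyl sulfur: a group of 9 heavy atoms (7 carbon, 2 nitrogen; one six-membered non-aromatic ring with 2 hetero atoms) in place of a group of 8 heavy atoms (7 carbon, 1 nitrogen; one four-membered non-aromatic ring of carbon only, one four-membered non-aromatic ring with 1 hetero atom), on a sulfonyl sulfur. The 4-isopropylpiperazin-1-yl group takes the place of the group with the two four-membered rings.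

With so few numbers, any expectation is loose. It rests on compound 2 at 303 ng.h/mL, and a fall in circulating compound is expected, probably a moderate one that may not clear the scatter. The expected change is a 2.3-fold lower number from compound 3 to compound 4 (0.37 log units; beyond the scatter). For compound 4 the estimate is 450 ng.h/mL, with an expected range from 130 ng.h/mL to 1200 ng.h/mL.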

Compound 4, area under the concentration-time curve: 52.9 ng.h/mL
Beside the measured number, compound 4's estimate is 8.5-fold (0.93 log units) above it, and the stated range ends above it.
By their numbers in this assay, from the lowest: compound 4; then compound 2; then compound 3.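

In this assay, the group on the sulfonyl sulfur proves to be a place where a single exchange can shift the result greatly: 4-isopropylpiperazin-1-yl in place of the group with the two four-membered rings gives a 20-fold lower number from compound 3 to compound 4 (1.30 log units; beyond the scatter) as a large step. Within the data shown here, this is the first step here between compounds that differ in one place, so the earlier compounds could not show that this position alone, with the rest of the molecule unchanged, carries a difference of this size. Nothing available bears on what lies behind the step.

The compounds shown leave open whether the step follows from the isopropyl group or from the piperazine ring itself. They also leave open how a morpholine or an open-chain dimethylamino group on the sulfonyl sulfur would read in this assay on the same core.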